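A Small Amide Change in a Series at the Assay Limit

A few compounds are considered here, and "the series" means these few. Any claim that something is new, unique, unknown or untested is made for them only; others in the source may bear on it.

Of the compounds shown here, three built on one shared core have been tested in an assay on Sf9 cells for inhibition of mitogen-activated protein kinase kinase kinase 14 (Homo sapiens), read by ADP-Glo, with a stated time of 60 min; on this read-out lower numbers stand for stronger inhibition and higher numbers for weaker inhibition. Compound 1 `Cc1[nH]nc(N)c1-c1ccc(Cl)c(Cl)c1` gives only a limit of the assay, > 100000 nM. Compound 2 `CCCC(=O)n1nc(C)c(-c2ccc(Cl)c(Cl)c2)c1N` likewise gives only a limit, > 100000 nM. For the measured compounds named here, compound 3 `Cc1[nH]nc(NC(=O)c2ccccn2)c1-c1ccc(Cl)c(Cl)c1` also stands at a limit, > 100000 nM, the same edge of the measurable range where every value so far sits (the limit of > 100000 nM in this assay, at which 3 of the 3 values shown sit). Compound 4 `Cc1[nH]nc(NC(=O)C(F)(F)F)c1-c1ccc(Cl)c(Cl)c1` differs from compound 3 in one place: trifluoromethyl in place of pyridin-2-yl on a carbonyl carbon. Going by the values given here, no step between measured compounds is available, so the expectation rests solely on all three values being limits. The change is expected to alter this assay reading by nothing beyond the scatter, a step of a number no higher from compound 3 to compound 4 (the limit leaves the size open). Compound 4 is therefore estimated at 100000 nM, within 30000 nM to 500000 nM, most likely reported again only as a limit.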

Compound 4, half-maximal inhibitory concentration: > 100000 nM
Compound 4: no number, only a limit (the forecaster's own chance of this, stated with the estimate: 85%); the middle value sits exactly at the limit.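

Compound 1, compound 3 and compound 4 all give only a limit in this assay, so no step among them can be read: the limit of > 100000 nM in this assay, at which 4 of the 4 values shown sit.

The compounds shown leave open whether any change to the shared core brings a measurable number.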